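The source may report more compounds than this note shows. Statements on the series, on what has been measured and on what is new or still open speak of the compounds shown alone.

Among the measured compounds shown here, compound 2 `Oc1nc2nonc2nc1Nc1cccc(S(F)(F)(F)(F)F)c1` gives 3700 nM in an assay on mitochondria from L6 cells (Rattus norvegicus) for activation, with a stated time of 90 min (on this read-out higher numbers stand for an effect only at larger amounts of compound and lower numbers for an effect already at smaller amounts), the lowest of the two numbers known here. Compound 1 `Oc1nc2nonc2nc1Nc1ccccc1F` gives 12500 nM in this assay, a step that lies beyond the usual scatter. Compound 3 `Cc1cccc(C)c1Nc1nc2nonc2nc1O` reaches only > 100000 nM in this assay; that is a limit of the assay, not a number, the one given as the limit of > 100000 nM in this assay, at which 1 of the 3 values shown sits. Compound 4 `CC(C)(C)c1cccc(Nc2nc3nonc3nc2O)c1` has not yet been measured. It differs from compound 2 by a group of 4 heavy atoms (4 carbon; no ring) in place of a group of 6 heavy atoms (5 fluorine, 1 sulfur; no ring), on an aromatic carbon, the tert-butyl standing on the same aromatic carbon, meta to a large group. For the measured compounds named here, no measured step of this kind exists. The change from compound 2 to compound 4 is expected to be modest, a 2.2-fold higher number from compound 2 to compound 4 (0.33 log units; beyond the scatter), toward a somewhat weaker effect. Compound 4 is thus estimated at 8000 nM in this assay, between 2500 nM and 30000 nM.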

Compound 4, half-maximal effective concentration: 2200 nM
Estimate against measurement, compound 4: 3.6-fold (0.56 log units) above; the whole stated range lies above it.
By their numbers in this assay, from the lowest: compounds 4 and 2 (each within the scatter of the next); then compound 1. At a limit, above all of these: compound 3.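

In this assay, putting tert-butyl on this aromatic carbon in place of the group of fluorine and sulfur gives a 1.7-fold lower number from compound 2 to compound 4 (0.23 log units; within the scatter), so the two groups cannot be told apart here. This position therefore accepts a group made only of carbon as well as one with no carbon at all, which compound 2 alone could not show. Nothing measured here explains this match.

As far as these compounds go, neither group has hydrogen-bond donors or acceptors, so how an amine or a carboxylic acid on this same aromatic carbon would fare remains open.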